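A few compounds are considered here, and "the series" means these few. Any claim that something is new, unique, unknown or untested is made for them only; others in the source may bear on it.

Compound 1 `CCN1CC(NC(=O)[C@@H]2CCCN(S(=O)(=O)c3ccc(S(=O)(=O)N(CC)CC)cc3)C2)C1` stands at the edge of what a functional assay on MIA PaCa-2 cells (Homo sapiens) for inhibition, read by MTT assay, with a stated time of 3 days (on this read-out higher numbers stand for weaker inhibition and lower numbers for stronger inhibition), reports: its reading of > 10000 nM is a limit rather than a number (the limit of > 10000 nM in this assay, at which 1 of the 3 values shown sits). Compound 2 `CCN(CC)S(=O)(=O)c1ccc(S(=O)(=O)N2CCC[C@@H](C(=O)NC3CN(C(=O)OC(C)(C)C)C3)C2)cc1` gives 100 nM in this assay, and compound 3 `CCN(CC)S(=O)(=O)c1ccc(S(=O)(=O)N2CCC[C@@H](C(=O)N[C@H]3CCN(C(=O)OC(C)(C)C)C3)C2)cc1` gives 170 nM. The steps away from compound 1 were large: an at least 100-fold lower number from compound 1 to compound 2 (2.00 log units; beyond the scatter) and an at least 58-fold lower number from compound 1 to compound 3 (1.76 log units; beyond the scatter); between the two, a 1.7-fold higher number from compound 2 to compound 3 (0.23 log units; within the scatter). Compound 4 `CCN(CC)S(=O)(=O)c1ccc(S(=O)(=O)N2CCC[C@@H](c3cc(C)no3)C2)cc1` departs from compound 1 in a different way: 3-methyl-1,2-oxazol-5-yl in place of (1-ethylazetidin-3-yl)carbamoyl on a saturated ring carbon. Within the data shown here, no measured step covers this replacement; the two large steps from compound 1 show only that changing what sits at this position can move the number far. Compound 4 is therefore expected to show a lower number, an at least 3.3-fold lower number from compound 1 to compound 4 (0.52 log units; beyond the scatter), estimated at 3000 nM within 300 nM to 30000 nM, though another limit remains possible.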

Compound 4, half-maximal inhibitory concentration: 2700 nM
Compound 4: middle estimate off by 1.1-fold (0.05 log units), on the high side; the range from low to high includes it.
By their numbers in this assay, from the lowest: compounds 2 and 3 (each within the scatter of the next); then compound 4. At a limit, above all of these: compound 1.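

In this assay, the change on this saturated ring carbon gives an at least 3.7-fold lower number from compound 1 to compound 4 (0.56 log units; beyond the scatter), so a lower number here does not depend on keeping the carbamoyl link or on a tert-butoxycarbonyl group. The 3-methyl-1,2-oxazol-5-yl group has 0 hydrogen-bond donors, so the amide hydrogen is not needed for this step. The true size of the step stays unknown because compound 1 sits at a limit: the limit of > 10000 nM in this assay, at which 1 of the 4 values shown sits.

Going by these compounds, whether a carboxylic acid or a phenyl ring on this carbon would give a lower number than the 3-methyl-1,2-oxazol-5-yl group stays open. So does the effect of removing that group's methyl.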